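Swapping a bromophenyl for a fluorophenyl on two cores

The compounds below may be only part of what the source reports. "The series", "measured", "known", "first", "only" and "open" are said of these compounds alone.

Measured so far in a functional assay on U-937 cells (Homo sapiens) for antiproliferative activity, read by MTT assay; on this read-out higher numbers stand for weaker inhibition and lower numbers for stronger inhibition:
Compound 1, `COc1ccc2nc(N(Cc3cc(-c4ccc(Br)cc4)no3)c3nc4ccc(F)cc4s3)sc2c1`, gives 34900 nM.
Compound 2, `COc1ccc2nc(N(Cc3cc(-c4ccccc4F)no3)c3nc4ccc(F)cc4s3)sc2c1`, gives 29500 nM.
Compound 3, `Brc1ccc(-c2cc(CN(c3ncccn3)c3nc4ccccc4s3)on2)cc1`, gives 13600 nM.

Compound 1 and compound 2 share one core and differ by 2-fluorophenyl in place of 4-bromophenyl on an aromatic carbon. That change gave a 1.2-fold lower number from compound 1 to compound 2 (0.07 log units; within the scatter). Compound 3 sits on a different core; the difference between the two cores is not broken down here. Compound 3 has the lowest number of the three, beyond the scatter from both compound 1 and compound 2.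

Compound 4, `Fc1ccccc1-c1cc(CN(c2ncccn2)c2nc3ccccc3s2)on1`, is not yet measured. For the measured compounds named here, it differs from compound 3 by 2-fluorophenyl in place of 4-bromophenyl on an aromatic carbon, the same change as the one between compound 1 and compound 2. Because a 1.2-fold lower number from compound 1 to compound 2 (0.07 log units; within the scatter) was small, the step here is also expected to be small, at a 1.2-fold lower number from compound 3 to compound 4 (0.07 log units; within the scatter). Compound 4 is therefore estimated at 11500 nM, between 5000 nM and 28000 nM.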

Compound 4, half-maximal inhibitory concentration: 27600 nM
For compound 4 the middle estimate is 2.4-fold (0.38 log units) below the measured one; measured number inside the range.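

On the second core, replacing 4-bromophenyl with 2-fluorophenyl gave a 2.0-fold higher number from compound 3 to compound 4 (0.31 log units; beyond the scatter), whereas on the core of compound 1 the same swap stayed within the scatter. Set side by side, the two steps do not differ by more than repeated measurements could produce: the same change on two cores in this assay, a 1.2-fold lower number (0.07 log units; within the scatter) from compound 1 to compound 2 and a 2.0-fold higher number (0.31 log units; beyond the scatter) from compound 3 to compound 4, 2.4-fold (0.38 log units) apart, within the scatter of two such steps. The swap may therefore act alike on both cores in this assay, but a single pair on each core does not prove that the steps are the same.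

The swap alters both the halogen and its place on the phenyl ring, and the compounds shown leave open which of the two matters. A 4-fluorophenyl or a 2-bromophenyl group on each core would separate these two changes.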